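Carbonyl substituent step from compound 3 to compound 4

The source may hold more compounds than are shown below. What is called first, only, known or untested is meant among the compounds shown, and "the series" means these compounds.

Values in an ADME assay on HepG2 cells (Homo sapiens) for cytotoxicity (a lower number here means that less compound is needed, a higher number that more compound is needed for the effect), each one a limit:
Compound 1 `Cc1ccc(S(=O)(=O)N[C@@H](CC(=O)NC(C)(C)C)C(=O)NCCNC(=O)c2ccccc2Cl)cc1`: > 11000 nM
Compound 2 `COc1cc(OC)cc(C(=O)NCCNC(=O)[C@H](CC(=O)NC(C)(C)C)NS(=O)(=O)c2ccc(C)cc2)c1`: > 11000 nM
Compound 3 `Cc1ccc(S(=O)(=O)N[C@@H](CC(=O)NC(C)(C)C)C(=O)NCCNC(=O)c2cccc(C#N)c2)cc1`: > 11000 nM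

Compound 3 stands at > 11000 nM, which is a limit and not a number. The series offers only (the limit of > 11000 nM in this assay, at which 3 of the 3 values shown sit).

Compound 4 `Cc1ccc(S(=O)(=O)N[C@@H](CC(=O)NC(C)(C)C)C(=O)NCCNC(=O)NCc2ccccc2)cc1` carries benzylamino in place of 3-cyanophenyl on a carbonyl carbon, and the difference reads: benzylamino in place of 3-cyanophenyl on a carbonyl carbon.

Three measured steps change the group on this same carbonyl carbon: a step that the two limits leave unreadable from compound 1 to compound 3, a step that the two limits leave unreadable from compound 2 to compound 3 and a step that the two limits leave unreadable from compound 1 to compound 2. None of them gives a size, and none involves benzylamino. The expectation therefore rests on the three limits alone, and compound 4 is expected to report a limit in this assay as well. No step beyond the scatter is expected, in either direction. The estimated change is a step that the limit leaves unreadable from compound 3 to compound 4. For compound 4 the estimated value is 16000 nM, with an expected range of 7000 nM to 40000 nM.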

Compound 4, half-maximal effective concentration: > 11000 nM
Compound 4: no number, only a limit; the forecaster's own chance of this, stated with the estimate: 85%; the middle value does not contradict the limit.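

In this assay compound 4 gives > 11000 nM, a limit and not a number. Its steps from compound 1, compound 2 and compound 3 therefore cannot be read. The compounds shown leave open whether the group on this carbonyl carbon changes the read-out at all: the limit of > 11000 nM in this assay, at which 4 of the 4 values shown sit.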